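A few compounds are considered here, and "the series" means these few. Any claim that something is new, unique, unknown or untested is made for them only; others in the source may bear on it.

Compound 1 `CCn1cc(-c2nc3ccc(Cl)cc3[nH]2)c(=O)c2cc(F)c(N3CCNCC3)nc21` and compound 2 `CCn1cc(-c2nc3ccc(Cl)cc3[nH]2)c(=O)c2cc(F)c(N3CCNCC3)cc21` are built on two closely related cores; the difference between the two cores is not broken down here. In a functional assay on A2780 cells (Homo sapiens) for cytotoxicity, read by MTT assay, with a stated time of 48 h (a higher number here means a weaker inhibitor, a lower number a stronger inhibitor), compound 1 gives 6300 nM, and compound 2 gives 4900 nM, two numbers that lie within the usual scatter of each other. Compound 3 `CCn1cc(-c2nc3ccc([N+](=O)[O-])cc3[nH]2)c(=O)c2cc(F)c(N3CCNCC3)cc21` is the core of compound 2 with a single change: nitro in place of chloro on an aromatic carbon. In this assay compound 3 gives 1600 nM, so that the change produced a 3.1-fold lower number from compound 2 to compound 3 (0.49 log units; beyond the scatter).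

Compound 4 `CCn1cc(-c2nc3ccc([N+](=O)[O-])cc3[nH]2)c(=O)c2cc(F)c(N3CCNCC3)nc21` has not yet been measured. It is the core of compound 1 carrying the same change: nitro in place of chloro on an aromatic carbon. The place around the group is described in the same words for both pairs, so the change made from compound 1 to compound 4 is the same change as that made from compound 2 to compound 3, only set on the other core. Going by the values given here, the two cores start from values within the scatter of each other, and only one measured instance of the change is available, so the expectation rests on that single step, a 3.1-fold lower number from compound 2 to compound 3 (0.49 log units; beyond the scatter), as a guide. A step of similar size is expected here, a 3.2-fold lower number from compound 1 to compound 4 (0.50 log units; beyond the scatter). For compound 4 the estimated value in this assay is 2000 nM, with a range from 1000 nM to 4500 nM.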

Compound 4, half-maximal inhibitory concentration: 12400 nM
Beside the measured number, compound 4's estimate is 6.2-fold (0.79 log units) below it, and the stated range ends below it.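

Set side by side in this assay, the same swap of chloro for nitro does not behave alike on the two cores, and the gap between the two steps is larger than repeated measurements would explain: the same change on two cores in this assay, a 3.1-fold lower number (0.49 log units; beyond the scatter) from compound 2 to compound 3 and a 2.0-fold higher number (0.29 log units; within the scatter) from compound 1 to compound 4, 6.0-fold (0.78 log units) apart, beyond the scatter of two such steps On the core of compound 1 the step, a 2.0-fold higher number from compound 1 to compound 4 (0.29 log units; within the scatter), is too small to count as a real change, so the gain seen on the core of compound 2 did not carry over, and a step measured on one core proved a poor guide to the other in this pair of cores. What this does not show is why the cores part ways, or whether the mismatch is a general feature of the series, since each core offers a single pair of compounds and the structural difference between the cores has not been broken down here.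

The compounds shown leave open whether other groups in the place of chloro, such as an amine, a nitrile or a carboxylic acid, would also respond differently on the two cores. They also leave open whether a longer chain in place of the ethyl group would alter the picture.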